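Extending the side chain on a cysteinyl leukotriene antagonist core

A few compounds are considered here, and "the series" means these few. Any claim that something is new, unique, unknown or untested is made for them only; others in the source may bear on it.

Measured compounds:
compound 1, `CCCCCCCCc1ccccc1C(SCCC(=O)O)SCCC(=O)O`, 5670 nM
compound 2, `CCCCCCCCCCC#Cc1ccccc1C(SCCC(=O)O)SCCC(=O)O`, 2520 nM
compound 3, `CCCCCCCCCC/C=C\c1ccccc1C(SCCC(=O)O)SCCC(=O)O`, 1380 nM

All three share the same core and were tested in an assay on membranes from lung (Cavia porcellus) for binding affinity to cysteinyl leukotriene receptor (Homo sapiens); a higher number here means a weaker inhibitor, a lower number a stronger inhibitor. Compound 1 gives the highest number of the three, so it is the weakest binder here; compound 2 and compound 3 sit lower, each beyond the scatter. Among the compounds with values here, no pair of measured compounds differs in only one place, so no single step can be read off directly.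

Compound 4, `CCCCc1ccc(CCCCc2ccccc2C(SCCC(=O)O)SCCC(=O)O)cc1`, is not yet measured. It differs from compound 1 by 4-butylphenyl in place of butyl on a saturated chain carbon, four bonds along the chain from an aromatic carbon. The lower numbers of compound 2 and compound 3, which carry longer chains, suggest that a longer side chain helps. The expectation is that the step of a 3.8-fold lower number from compound 1 to compound 4 (0.58 log units; beyond the scatter) goes toward stronger binding, beyond the scatter. Compound 4 is therefore expected to give about 1500 nM, with a range from 500 nM to 5000 nM.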

Compound 4, inhibition constant: 4230 nM
Estimate against measurement, compound 4: 2.8-fold (0.45 log units) below; measured number inside the range.
By their numbers in this assay, from the lowest: compounds 3, 2, 4 and 1 (each within the scatter of the next, the first and the last beyond it).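

In this assay, placing 4-butylphenyl in place of butyl on a saturated chain carbon gives a 1.3-fold lower number from compound 1 to compound 4 (0.13 log units; within the scatter) and so no real change. At this position, then, the added aromatic ring brings no measurable gain in binding, so extra chain length of this kind is not enough on its own to lower the number. Nothing available here explains this result.

From the compounds shown here alone, it remains open whether an amine or a carboxylic acid on that new ring would move the number beyond the scatter. Also open, going by these compounds, is how a longer saturated chain without a ring would compare with compound 3.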